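The source may hold more compounds than are shown below. What is called first, only, known or untested is meant among the compounds shown, and "the series" means these compounds.

Measured compounds, each in a functional assay on HeLa cells (Homo sapiens) for cytotoxicity, read by MTT assay, with a stated time of 24 h; a higher number here means a weaker inhibitor, a lower number a stronger inhibitor:
Compound 1 `C=CC1=C(C(=O)NCc2ccccc2)C(c2ccc(OC)c(OC)c2)OC1` reaches only the assay limit, > 100000 nM.
Compound 2 `C=CC1=C(C(=O)NCc2ccccc2)C(c2ccc(OC)cc2)OC1` likewise returns only the limit > 100000 nM.
Compound 3 `C=CC1=C(C(=O)NCc2ccccc2)C(c2ccc(F)cc2)OC1` also stops at the limit > 100000 nM.

Going by the values given here, compound 2 stands nowhere on a scale: its value in this assay is a limit, as the limit of > 100000 nM in this assay, at which 3 of the 3 values shown sit, records for every value so far. Compound 4 `C=CC1=C(C(=O)NCC(C)C)C(c2ccc(OC)cc2)OC1` differs from compound 2 by isopropyl in place of phenyl on a saturated chain carbon bound to an amide-type nitrogen. Among the compounds with values here, the measured steps change an aromatic carbon, not the saturated chain carbon bound to the amide-type nitrogen, and a step that the two limits leave unreadable from compound 1 to compound 2 and a step that the two limits leave unreadable from compound 2 to compound 3 are both unreadable between two limits, so no measured step bears on the new change. With every value at the limit, compound 4 is expected to return a limit as well, an expected step of a number no higher from compound 2 to compound 4 (the limit leaves the size open). The estimate for compound 4 is 100000 nM, from 30000 nM to 300000 nM.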

Compound 4, half-maximal inhibitory concentration: > 100000 nM
Compound 4: a limit, no number (the forecaster's own chance of this, stated with the estimate: 85%); the middle value sits exactly at the limit.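

Compound 2 and compound 4 each return only a limit, so no step can be read between them. The compounds shown leave open which change, if any, would give a readable number: the limit of > 100000 nM in this assay, at which 4 of the 4 values shown sit.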